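Benzyl to methyl at selenium: outlook for compound 3

The source may report more compounds than this note shows. Statements on the series, on what has been measured and on what is new or still open speak of the compounds shown alone.

Compound 1 `CS/C(=N\C(=O)c1ccno1)NC(=O)c1ccno1` is the methylthio member of the series. In a functional assay on MCF7 cells (Homo sapiens) for cytotoxicity, read by MTT assay, with a stated time of 72 h (a lower number here means that less compound is tolerated, a higher number that more compound is tolerated), compound 1 gives only a limit, > 100000 nM. Compound 2 `O=C(/N=C(/NC(=O)c1ccno1)[Se]Cc1ccccc1)c1ccno1` carries the benzylseleno group in its place. In this assay compound 2 likewise gives only a limit, > 100000 nM. The step that the two limits leave unreadable from compound 1 to compound 2 therefore cannot be read. For the measured compounds named here, compound 2 thus stands at the edge of what this assay reports, as does the one other value shown, (the limit of > 100000 nM in this assay, at which 2 of the 2 values shown sit). Compound 3 `C[Se]/C(=N\C(=O)c1ccno1)NC(=O)c1ccno1` differs from compound 2 by hydrogen in place of phenyl on a saturated chain carbon bound to a selenium atom, which cut one bond further out reads benzyl to methyl. Going by the values given here, the only measured step bearing on it is unreadable, and both neighbours sit at the limit, so no change beyond the scatter is expected, and compound 3 is expected to sit near the limit again, with the step estimated as a step that the limit leaves unreadable from compound 2 to compound 3. Compound 3 is therefore estimated at 150000 nM, within 50000 nM to 500000 nM.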

Compound 3, concentration lethal to 50% of the cells: > 100000 nM
Compound 3 was reported as a limit (the forecaster's own chance of this, stated with the estimate: 80%); the middle value lies beyond the limit too.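

In this assay compound 3 gives only a limit, > 100000 nM. No step among compound 1, compound 2 and compound 3 can therefore be read: the limit of > 100000 nM in this assay, at which 3 of the 3 values shown sit.

The compounds shown leave open whether benzyl to methyl, or sulfur to selenium, changes the result in this assay at all.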